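This account rests on a few compounds, and the source may have more. Where it says the series, first, only, none or still open, it means among the compounds named here.

Four compounds are compared here. Compound 1 `COc1cccc(-c2cccc(NC(=O)CCc3cccc4c3COB4O)c2)c1` carries a methoxy group on its outer ring, and compound 2 `COc1cc(OC)cc(-c2cccc(NC(=O)CCc3cccc4c3COB4O)c2)c1` differs from it by methoxy in place of hydrogen on an aromatic carbon. Compound 3 `COc1cccc(-c2cccc(NC(=O)CCc3ccccc3)c2)c1` keeps the same outer ring as compound 1 but has a different core, and the difference between the two cores is not broken down here. Compound 4 `COc1cc(OC)cc(-c2cccc(NC(=O)CCc3ccccc3)c2)c1`, not yet measured, stands to compound 3 as compound 2 stands to compound 1: methoxy in place of hydrogen on an aromatic carbon, the same change at the same kind of position.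

In an ADME assay on WI-38 cells (Homo sapiens) for cytotoxicity, read by MTT assay, with a stated time of 72 h (a lower number here means a stronger inhibitor, a higher number a weaker inhibitor), compound 1 gives > 100000 nM, which is a limit of the assay rather than a number. Compound 2 gives > 100000 nM, again a limit. Compound 3 gives > 100000 nM, also a limit. Because all three values sit at the limit of > 100000 nM in this assay, at which 3 of the 3 values shown sit, the step that the two limits leave unreadable from compound 1 to compound 2 cannot be read in size: the measured range of the assay simply does not reach the compounds.

For compound 4 the same situation is expected. Within the data shown here, compound 3 is itself at the limit, and the one measured example of this change, from compound 1 to compound 2, stayed at the limit. The expected step is a step that the limit leaves unreadable from compound 3 to compound 4, essentially no readable change. Compound 4 is therefore expected to give 150000 nM, with a plausible range from 50000 nM to 500000 nM, most probably reported once more only as a limit.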

Compound 4, half-maximal inhibitory concentration: > 100000 nM
Compound 4 gave a limit, no number; the forecaster's own chance of this, stated with the estimate: 85%; the middle value does not contradict the limit.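

Neither step that compound 4 adds can be read in size, from compound 3 or from compound 2, because every compound sits at the same limit and none gives a number: the limit of > 100000 nM in this assay, at which 4 of the 4 values shown sit. The compounds shown leave open whether the added methoxy or the difference between the two cores changes the result in this assay at all, and by how much.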